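Carbamate to benzamide on the shared core

The compounds below may be only part of what the source reports. "The series", "measured", "known", "first", "only" and "open" are said of these compounds alone.

Compound 1, `CCn1nc(C)cc1C(=O)Nc1nc2cc(C(N)=O)cc(OC)c2n1CCCNC(=O)OCc1ccccc1`: in an assay for activation of interferon regulatory factor 3 (Homo sapiens), read by a luciferase reporter, with a stated time of 20 h (on this read-out lower numbers stand for an effect already at smaller amounts and higher numbers for an effect only at larger amounts of compound), compound 1 gives > 100000 nM, which is a limit of the assay and not a number.
Compound 2, `CCn1nc(C)cc1C(=O)Nc1nc2cccc(OC)c2n1CCCNC(=O)OCc1ccccc1`: in this assay compound 2 gives > 100000 nM, again a limit.

Compound 1 therefore stands only at a limit, and both values shown sit at that same limit, (the limit of > 100000 nM in this assay, at which 2 of the 2 values shown sit). Going by the values given here, the single measured step, a step that the two limits leave unreadable from compound 1 to compound 2, hydrogen in place of carbamoyl on an aromatic carbon, cannot be read in size or direction because both ends are limits.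

Compound 3, `CCn1nc(C)cc1C(=O)Nc1nc2cc(C(N)=O)cc(OC)c2n1CCCNC(=O)c1ccccc1`, differs from compound 1 by phenyl in place of benzyloxy on a carbonyl carbon, read one bond further out as benzyloxycarbonyl to benzoyl. Among the compounds with values here, no measured step touches this position, and the one step that exists, from compound 1 to compound 2, is unreadable, so no size or direction can be taken from the data. Given that the series so far produces only limits, the expectation is that compound 3 also stays at the limit. Compound 3 is estimated at 100000 nM (range 30000 nM to 300000 nM), an expected step of a number no higher from compound 1 to compound 3 (the limit leaves the size open).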

Compound 3, half-maximal effective concentration: > 100000 nM
Compound 3: a limit, no number; the forecaster's own chance of this, stated with the estimate: 80%; the middle value sits exactly at the limit.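

No step can be read between compound 1 and compound 3, since both ends are limits and not numbers: the limit of > 100000 nM in this assay, at which 3 of the 3 values shown sit.

The compounds shown leave open how benzoyl compares with benzyloxycarbonyl, or hydrogen with carbamoyl, and whether any change on the shared core gives a measurable number in this assay.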